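Moving the iodine around the ring on the triazole nitrogen

The source may hold more compounds than are shown below. What is called first, only, known or untested is meant among the compounds shown, and "the series" means these compounds.

Three compounds share one core and differ only in the aryl group attached to the triazole nitrogen. In a functional assay on HepG2 cells (Homo sapiens) for inhibition, read by MTT assay, with a stated time of 72 h (a lower number here means a stronger inhibitor, a higher number a weaker inhibitor), compound 1 `N#Cc1ccccc1-n1cc(COc2cccc(NC(=O)Nc3ccc(Cl)c(C(F)(F)F)c3)c2)nn1` gives 1970 nM. Compound 2 `O=C(Nc1cccc(OCc2cn(-c3cccc(Cl)c3)nn2)c1)Nc1ccc(Cl)c(C(F)(F)F)c1` gives 2020 nM, and compound 3 `O=C(Nc1cccc(OCc2cn(-c3ccccc3I)nn2)c1)Nc1ccc(Cl)c(C(F)(F)F)c1` gives 2870 nM. All three numbers sit within the usual scatter of one another, so compound 3 stands level with the other two rather than apart from them.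

Compound 4 `O=C(Nc1cccc(OCc2cn(-c3ccc(I)cc3)nn2)c1)Nc1ccc(Cl)c(C(F)(F)F)c1` is the next step: 4-iodophenyl in place of 2-iodophenyl on an aromatic nitrogen. The measured steps that bear on this change all concern swaps of this same aryl group, and none of them moved the number beyond the scatter: a 1.0-fold higher number from compound 1 to compound 2 (0.01 log units; within the scatter), a 1.4-fold higher number from compound 2 to compound 3 (0.15 log units; within the scatter) and a 1.5-fold higher number from compound 1 to compound 3 (0.16 log units; within the scatter). Going by the values given here, since every change at this position so far, including one that moved a substituent and one that exchanged it, has left this assay essentially unchanged, a shift of the iodine to a different ring position is expected to do the same.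

Compound 4 is therefore estimated at 2500 nM, with a range of 1100 nM to 6000 nM, which means an expected step of a 1.1-fold lower number from compound 3 to compound 4 (0.06 log units; within the scatter).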

Compound 4, half-maximal inhibitory concentration: 2690 nM
For compound 4 the middle estimate is 1.1-fold (0.03 log units) below the measured one, and the stated range covers the measured number.
By their numbers in this assay, from the lowest: compounds 1, 2, 4 and 3 (each within the scatter of the next).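

Moving the iodine, with 2-iodophenyl giving way to 4-iodophenyl on the aromatic nitrogen, changes how the same atoms are joined and leaves this assay level (a 1.1-fold lower number from compound 3 to compound 4 (0.03 log units; within the scatter)). Compound 4 also stays level with the other two aryl groups (a 1.3-fold higher number from compound 2 to compound 4 (0.12 log units; within the scatter); a 1.4-fold higher number from compound 1 to compound 4 (0.14 log units; within the scatter)), so all four compounds now lie within the scatter of one another, and among these groups neither the iodine's ring position nor the choice of substituent shows a readable effect. Nothing measured here offers an explanation for this sameness.

Every group shown at this place is a phenyl ring bearing iodo, chloro or cyano, which leaves open whether an amine, a carboxylic acid or a longer chain there would shift the number beyond the scatter. Also open, going by these compounds, is whether a change elsewhere in the shared core would matter more.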